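This account rests on a few compounds, and the source may have more. Where it says the series, first, only, none or still open, it means among the compounds named here.

Measured so far in an ADME assay on HaCaT cells (Homo sapiens) for inhibition, read by sulforhodamine B assay, with a stated time of 48 h; on this read-out lower numbers stand for stronger inhibition of growth and higher numbers for weaker inhibition of growth:

- compound 1 `CC(C)(C)NCc1c(C(=O)O)nn(-c2ccccc2)c1-c1ccc(Br)cc1`; compound 1 gives 366000 nM
- compound 2 `CC(C)(C)NCc1c(C(=O)O)nn(-c2ccccc2)c1-c1ccccc1`; compound 2 gives only a limit of the assay, > 716000 nM
- compound 3 `CC(C)(C)NCc1c(C(=O)O)nn(-c2ccc(Cl)cc2)c1-c1ccc(Br)cc1`; compound 3 gives only a limit of the assay, > 542000 nM

Compound 4 `CC(C)(C)NCc1c(C(=O)O)nn(-c2ccc(Cl)cc2)c1-c1ccccc1` has not been measured. It differs from compound 3 in one place: hydrogen in place of bromo on an aromatic carbon. The same change is made from compound 1 to compound 2, namely (hydrogen in place of bromo on an aromatic carbon), and the two "place" descriptions agree word for word, so the change is the same in both pairs. Between compound 1 and compound 2 it produced an at least 1.9-fold higher number from compound 1 to compound 2 (0.29 log units; that floor lies within the scatter); that step is only a floor because compound 2 sits at the limit of > 716000 nM in this assay, at which 1 of the 3 values shown sits.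

The cores of the two pairs differ in one place as well: chloro in place of hydrogen on an aromatic carbon. That difference gave an at least 1.4-fold higher number from compound 1 to compound 3 (0.17 log units; that floor lies within the scatter), again only a floor because compound 3 sits at the limit of > 542000 nM in this assay, at which 1 of the 3 values shown sits. Both floors lie within the usual scatter, so neither step can be called a real change on the strength of the numbers shown.

For compound 4 the step that the limit leaves unreadable from compound 3 to compound 4 in this assay is expected, in line with the earlier one, because the measured pair shows an at least 1.9-fold higher number from compound 1 to compound 2 (0.29 log units; that floor lies within the scatter) and the starting point, compound 3, is itself at a limit. Compound 4 is therefore expected to give a limit rather than a number in most repeats. The estimate for compound 4 is 900000 nM, with a range from 450000 nM to 2000000 nM.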

Compound 4, concentration for 50% growth inhibition: 175000 nM
Beside the measured number, compound 4's estimate is 5.1-fold (0.71 log units) above it, outside the stated range (below it).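

In this assay, the change from 4-bromophenyl to phenyl gives an at least 3.0-fold lower number from compound 3 to compound 4 (0.49 log units; beyond the scatter), so it does not carry over unchanged from the core of compound 1 to the core of compound 3: the same change on two cores in this assay, an at least 1.9-fold higher number (0.29 log units; that floor lies within the scatter) from compound 1 to compound 2 and an at least 3.0-fold lower number (0.49 log units; beyond the scatter) from compound 3 to compound 4, at least 6.0-fold (0.78 log units) apart, beyond the scatter of two such steps

Chloro in place of hydrogen on an aromatic carbon gives an at least 4.0-fold lower number from compound 2 to compound 4 (0.61 log units; beyond the scatter), and it too reads differently on the two cores: the same change on two cores in this assay, an at least 1.4-fold higher number (0.17 log units; that floor lies within the scatter) from compound 1 to compound 3 and an at least 4.0-fold lower number (0.61 log units; beyond the scatter) from compound 2 to compound 4, at least 6.0-fold (0.78 log units) apart, beyond the scatter of two such steps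

Compound 2 and compound 3 sit at limits of the assay, so these steps and the gaps between them are floors: they show that neither change can be carried from one core to the other in this set, but not how large the true steps are, and the finding rests on these four compounds alone.

Open, on these data alone, is whether the same dependence on the core appears with other groups on the aromatic rings, such as fluoro or methoxy, or when the carboxylic acid gives way to an amide. Also open, as far as these compounds go, is what numbers compound 2 and compound 3 would give in a read-out that reaches past their limits, which would fix the real size of each step.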